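Swapping Fluoro for Methoxy Where the Limit Already Rules

A few compounds are considered here, and "the series" means these few. Any claim that something is new, unique, unknown or untested is made for them only; others in the source may bear on it.

Compound 1, `[O-]/[N+](=C\c1cn(-c2ccc(F)cc2)nn1)c1ccccc1`, gives 10200 nM in a functional assay on COLO 205 cells (Homo sapiens) for inhibition, read by MTT assay, with a stated time of 24 h; on this read-out lower numbers stand for stronger inhibition and higher numbers for weaker inhibition.
Compound 2, `[O-]/[N+](=C\c1cn(-c2ccccc2)nn1)Cc1ccccc1`, sits at the assay limit of > 100000 nM in this assay.
Compound 3, `[O-]/[N+](=C\c1cn(-c2ccc(F)cc2)nn1)Cc1ccccc1`, sits at the assay limit of > 100000 nM in this assay.

Compound 3 thus stands at the upper limit of this assay, where no number is obtained; the same holds for one other value shown (the limit of > 100000 nM in this assay, at which 2 of the 3 values shown sit). The step from compound 1 to compound 3, benzyl in place of phenyl on a double-bonded nitrogen, is an at least 9.8-fold higher number from compound 1 to compound 3 (0.99 log units; beyond the scatter). The step from compound 2 to compound 3, fluoro in place of hydrogen on an aromatic carbon, is a step that the two limits leave unreadable from compound 2 to compound 3.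

Compound 4, `COc1ccc(-n2cc(/C=[N+](\[O-])Cc3ccccc3)nn2)cc1`, differs from compound 3 by methoxy in place of fluoro on an aromatic carbon. Going by the values given here, only the step from compound 2 to compound 3 touches the same aromatic carbon, and it yields no readable size. Among the compounds with values here, no measured step therefore supports a change beyond the scatter in this assay for this substitution, and compound 4 is expected to remain at the limit as well. Compound 4 is estimated at 150000 nM, within 50000 nM to 500000 nM, most likely reported only as a limit. The estimated step that the limit leaves unreadable from compound 3 to compound 4 is expected to be none beyond the scatter.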

Compound 4, half-maximal inhibitory concentration: > 100000 nM
Compound 4 ended at the assay's limit; the forecaster's own chance of this, stated with the estimate: 80%; the middle value lies beyond the limit too.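

Compound 4, like compound 2 and compound 3, gives only a limit in this assay, so no step among these three compounds can be read: the limit of > 100000 nM in this assay, at which 3 of the 4 values shown sit.

The compounds shown leave open whether hydrogen, fluoro or methoxy on that aromatic carbon changes inhibition at all when benzyl stands on the double-bonded nitrogen.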